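Series notes on Vero cell toxicity: compound 2 to compound 3

The source may report more compounds than this note shows. Statements on the series, on what has been measured and on what is new or still open speak of the compounds shown alone.

compound 1 `COC(=O)c1cc(-c2cccc(NC(=O)c3ccc(/C=C/C(=O)c4ccc(C)c([N+](=O)[O-])c4)cc3)c2)on1` — an ADME assay on Vero cells (Chlorocebus sabaeus) for cytotoxicity, read by MTT assay, with a stated time of 72 h; on this read-out higher numbers stand for lower toxicity in this test and lower numbers for higher toxicity in this test: > 80 ug/mL
compound 2 `COC(=O)c1cc(-c2cccc(NC(=O)c3ccc(/C=C/C(=O)c4ccc(O)cc4)cc3)c2)on1` — this assay : "not determined" (no result reported)

In this assay compound 1 gives > 80 ug/mL; that figure is a limit of the assay and not a number (the limit of > 80 ug/mL in this assay, at which 1 of the 2 values shown sits). Compound 2 stands without any number in this assay, its entry reading "not determined" (no result reported). Compound 3 `COC(=O)c1cc(-c2cccc(NC(=O)c3ccc(/C=C/C(=O)c4ccc(CC(C)C)cc4)cc3)c2)on1` differs from compound 2 by isobutyl in place of hydroxy on an aromatic carbon. For the measured compounds named here, no step between measured compounds exists here, so for this assay the expectation is no shift beyond the scatter from the single limit seen. Compound 3 is expected at 70 ug/mL, in the range 30 ug/mL to 100 ug/mL.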

Compound 3, half-maximal cytotoxic concentration: > 10 ug/mL
Compound 3: only a limit was reported; the forecaster's own chance of this, stated with the estimate: 60%; the middle value is on the limit's open side.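

In this assay, compound 1 and compound 3 are each reported only as a limit, so no new step can be read between them. On these data alone, whether their toxicity differs at all remains open.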